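Fluorinated aryl dienones on the hydroxylated cyclohexenyl core

The source may report more compounds than this note shows. Statements on the series, on what has been measured and on what is new or still open speak of the compounds shown alone.

Measured so far:
- compound 1, `CC1=CCCC(C)(C)C1/C=C/C(=O)/C=C/c1cccc(C)c1`: 6200 nM
- compound 2, `CC1=C(/C=C/C(=O)/C=C/c2ccc(C(F)(F)F)cc2)C(C)(C)CCC1O`: "not determined" (no result reported)
- compound 3, `CC1=C(/C=C/C(=O)/C=C/c2cc(C(F)(F)F)cc(C(F)(F)F)c2)C(C)(C)CCC1O`: "not determined" (no result reported)

Compound 1 carries a methyl on its aryl ring and a core without the hydroxyl; in a functional assay on LNCaP C4-2B cells (Homo sapiens) for cytotoxicity, read by MTT assay, with a stated time of 72 h (on this read-out lower numbers stand for stronger inhibition and higher numbers for weaker inhibition), compound 1 gives 6200 nM. Compound 2 and compound 3 share the hydroxylated core and carry trifluoromethyl groups on the aryl ring, one and two of them; in this assay compound 2 gives "not determined" (no result reported) and compound 3 gives "not determined" (no result reported), so compound 2 stands without a value and has no measured neighbour on this read-out. Compound 4, `CC1=C(/C=C/C(=O)/C=C/c2ccc(F)cc2)C(C)(C)CCC1O`, keeps the core of compound 2 and differs from it only on the aryl ring: fluoro in place of trifluoromethyl on an aromatic carbon. Going by the values given here, no measured pair shows what a change of this kind does in this assay, so no direction can be taken from the data; the step from compound 2 to compound 4 is expected to stay within the scatter, with the sole anchor being compound 1 at 6200 nM. Compound 4 is therefore expected to fall near 5000 nM in this assay, within a range of 1500 nM to 20000 nM.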

Compound 4, half-maximal inhibitory concentration: 4000 nM
Compound 4: the middle estimate sits 1.3-fold (0.10 log units) above what was measured, within the range that was stated.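

In this assay compound 4 gives 4000 nM but no new step can be read, since compound 2 has no number and compound 1 differs from compound 4 in more than one place. The compounds shown leave open what exchanging trifluoromethyl for fluoro does on this read-out. No evidence bears on this result.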